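Coumarin-triazoles on pancreatic cells: pentyl to propylcyclohexyl

The compounds below may be only part of what the source reports. "The series", "measured", "known", "first", "only" and "open" are said of these compounds alone.

Measured compounds, in a functional assay on CFPAC-1 cells (Homo sapiens) for inhibition, read by MTT assay, with a stated time of 72 h; on this read-out lower numbers stand for stronger inhibition and higher numbers for weaker inhibition:
compound 1 `CCCCCCCCc1cn(Cc2cc(=O)oc3cc(O)ccc23)nn1`, 62700 nM
compound 2 `O=c1cc(Cn2cc(-c3ccc(Br)cc3)nn2)c2ccc(O)cc2o1`, 52900 nM
compound 3 `CCCCCc1ccc(-c2cn(Cc3cc(=O)oc4cc(O)ccc34)nn2)cc1`, 50400 nM

Compound 3 gives the smallest of the three numbers, yet its differences from compound 2 and from compound 1 lie within the scatter, so the three compounds cannot be told apart in this assay. Compound 4 `CCCC1CCC(c2ccc(-c3cn(Cc4cc(=O)oc5cc(O)ccc45)nn3)cc2)CC1` is obtained from compound 3 by 4-propylcyclohexyl in place of pentyl on an aromatic carbon. The two measured steps, a 1.2-fold lower number from compound 1 to compound 2 (0.07 log units; within the scatter) and a 1.0-fold lower number from compound 2 to compound 3 (0.02 log units; within the scatter), show that swapping the group on this aromatic carbon, whether chain or substituted phenyl, left this assay essentially unchanged. Compound 4 is therefore expected to stay in the same range, with a 1.1-fold lower number from compound 3 to compound 4 (0.05 log units; within the scatter) as the estimated step. Compound 4 is estimated at 45000 nM, with a range from 18000 nM to 110000 nM.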

Compound 4, half-maximal inhibitory concentration: 52800 nM
Compound 4: middle estimate off by 1.2-fold (0.07 log units), on the low side, and the stated range covers the measured number.
By their numbers in this assay, from the lowest: compounds 3, 4, 2 and 1 (each within the scatter of the next).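

In this assay, 4-propylcyclohexyl in place of pentyl gave a 1.0-fold higher number from compound 3 to compound 4 (0.02 log units; within the scatter) and 4-propylcyclohexyl in place of bromo gave a 1.0-fold lower number from compound 2 to compound 4 (0.00 log units; within the scatter). This aromatic carbon, para to a large group, thus carried 9 heavy atoms including a non-aromatic ring with no change beyond the scatter, something bromo and pentyl had not shown. Nothing measured here offers a reason for this flat response. From the compounds shown here alone, whether an amine or a carboxylic acid at this position would shift the number in this assay remains open, as does the effect of changing the shared core.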